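The source may hold more compounds than are shown below. What is called first, only, known or untested is meant among the compounds shown, and "the series" means these compounds.

Compound 1 `COc1ccc2nc(-c3ccc(N/C=C\C(=O)c4ccc(OC)c(F)c4)cc3)sc2c1`: 1300 nM
Compound 2 `COc1cc(OC)c2sc(-c3ccc(N/C=C\C(=O)c4ccc(OC)c([N+](=O)[O-])c4)c(C)c3)nc2c1`: 13900 nM
Compound 3 `COc1ccc2nc(-c3ccc(N/C=C\C(=O)c4cc(OC)c(OC)c(OC)c4Br)cc3)sc2c1`: 14700 nM

Of the compounds shown here, three have so far been tested in a functional assay on MIA PaCa-2 cells (Homo sapiens) for antiproliferative activity, read by sulforhodamine B assay, with a stated time of 48 h; a lower number here means a stronger inhibitor, a higher number a weaker inhibitor. Compound 1 gives the lowest of the three numbers; compound 2 and compound 3 both lie well beyond the usual scatter above it, so compound 1 is the strongest inhibitor of the measured set. Compound 4 `COc1ccc2nc(-c3ccc(N/C=C\C(=O)c4ccc(OC)c([N+](=O)[O-])c4)cc3)sc2c1` has not been measured yet. It differs from compound 1 in a single place: nitro in place of fluoro on an aromatic carbon. The same nitro group is present in compound 2, but compound 2 also differs from compound 1 elsewhere, so its value alone cannot fix what this one change does. A modest step towards a higher number is expected, a 2.3-fold higher number from compound 1 to compound 4 (0.36 log units; beyond the scatter). Compound 4 is estimated at 3000 nM, within a range from 900 nM to 10000 nM.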

Compound 4, half-maximal inhibitory concentration: 23600 nM
Beside the measured number, compound 4's estimate is 7.9-fold (0.90 log units) below it; measured number outside the range, above it.
By their numbers in this assay, from the lowest: compound 1; then compounds 2, 3 and 4 (each within the scatter of the next).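

In this assay nitro in place of fluoro brings an 18-fold higher number from compound 1 to compound 4 (1.26 log units; beyond the scatter) and nothing else in the molecule changes. Going by these compounds alone, this position, ortho to a methoxy group, therefore matters on its own: the single swap separates the two compounds by more than the usual scatter, which compound 2, differing from compound 1 in other places too, could not show.

Going by these compounds, whether a chloro group, an amine or a plain hydrogen at this place would stay nearer compound 1 or nearer compound 4 remains open. No measurement shown here explains the size of this step.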